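The source may hold more compounds than are shown below. What is called first, only, known or untested is meant among the compounds shown, and "the series" means these compounds.

Measured so far in a functional assay on DWD cells (Homo sapiens) for inhibition, read by sulforhodamine B assay; on this read-out lower numbers stand for stronger inhibition of growth and higher numbers for weaker inhibition of growth:
- compound 1 `Cc1ccc2[nH]c(-c3ccc(-c4ccc(-c5cccc(Cl)c5)cc4)cc3)nc2c1` gives 2510 nM
- compound 2 `COc1ccc(-c2ccc(-c3ccc(-c4nc5cc(C)ccc5[nH]4)cc3)cc2)cc1OC` gives 1720 nM
- compound 3 `Cc1ccc2[nH]c(-c3ccc(-c4ccc(-c5ccc(OC(F)(F)F)cc5)cc4)cc3)nc2c1` gives 41100 nM

Compound 3 has the highest number of the three (41100 nM). Compound 4 `Cc1ccc2[nH]c(-c3ccc(-c4ccc(-c5ccc(O)cc5)cc4)cc3)nc2c1` differs from it by one change (hydrogen in place of trifluoromethyl on an oxygen on an aromatic ring), hydrogen in place of trifluoromethyl on an oxygen on an aromatic ring, turning 4-(trifluoromethoxy)phenyl into 4-hydroxyphenyl. Among the compounds with values here, no measured step makes this exact change. The closest ones exchange that whole group (a 16-fold higher number from compound 1 to compound 3 (1.21 log units; beyond the scatter) and a 24-fold higher number from compound 2 to compound 3 (1.38 log units; beyond the scatter)), and both are large, whereas the remaining step (a 1.5-fold lower number from compound 1 to compound 2 (0.16 log units; within the scatter)) lies within the scatter. As far as these compounds go, compound 3 thus sits apart, so a clear downward step is expected in this assay (a 12-fold lower number from compound 3 to compound 4 (1.07 log units; beyond the scatter)), though the hydroxy group itself is untested. Compound 4 is estimated at 3500 nM (range 800 nM to 20000 nM).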

Compound 4, concentration for 50% growth inhibition: 21200 nM
Compound 4: the middle estimate sits 6.1-fold (0.78 log units) below what was measured; the measured number lies above the stated range.
By their numbers in this assay, from the lowest: compounds 2 and 1 (each within the scatter of the next); then compounds 4 and 3 (each within the scatter of the next).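

In this assay, hydrogen in place of trifluoromethyl on the oxygen leaves the number within the scatter (a 1.9-fold lower number from compound 3 to compound 4 (0.29 log units; within the scatter)), so this change makes no clear difference here. The high number of compound 3 is therefore not unique to trifluoromethoxy: 4-hydroxyphenyl also inhibits growth more weakly than 3,4-dimethoxyphenyl (a 12-fold higher number from compound 2 to compound 4 (1.09 log units; beyond the scatter)) and 3-chlorophenyl (an 8.4-fold higher number from compound 1 to compound 4 (0.93 log units; beyond the scatter)). No measurement shown explains this result. Still open, as far as these compounds go, is whether an amine, a carboxylic acid or a single methoxy group in place of the hydroxy group would match compound 4 or compound 2.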